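Replacing a terminal amine with a hydroxyphenoxy tail

The source may report more compounds than this note shows. Statements on the series, on what has been measured and on what is new or still open speak of the compounds shown alone.

Compound 1 `CC(=O)NCCN(C)c1cccc(OCCCCCCNC(=O)Oc2cccc(-c3ccccc3)c2)c1`: 33.1 nM
Compound 2 `CC(=O)NCCN(C)c1cccc(OCCCCOc2cccc(OC(=O)NC3CCCCC3)c2)c1`: 53.7 nM
Compound 3 `CC(=O)NCCN(C)c1cccc(OCCCCCCN)c1`: 398 nM

In an assay on cells for displacement of a labelled ligand from melatonin receptor type 1B (Homo sapiens), using the Cheng-Prusoff equation, with a stated time of 90 min (a higher number here means a weaker inhibitor, a lower number a stronger inhibitor), compound 3 gives the highest number of the three, and its gaps to compound 2 and to compound 1 are both beyond the scatter, so compound 3 is the weakest inhibitor among the measured compounds. Compound 4 `CC(=O)NCCN(C)c1cccc(OCCCCOc2cccc(O)c2)c1` is not yet measured. Its difference from compound 3 is 3-hydroxyphenoxy in place of 2-aminoethyl on a saturated chain carbon, four bonds along the chain from an oxygen on an aromatic ring. Compound 1 and compound 2, which both carry an aromatic tail on the chain, sit well below compound 3 in this assay; the hydroxyphenoxy group of compound 4 adds an aromatic ring but no further substituent, so a downward step of moderate size, beyond the scatter, is expected: a 3.6-fold lower number from compound 3 to compound 4 (0.56 log units; beyond the scatter). Compound 4 is estimated at 110 nM, within 35 nM to 320 nM.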

Compound 4, inhibition constant: 603 nM
For compound 4 the middle estimate is 5.5-fold (0.74 log units) below the measured one, and the stated range ends below it.
By their numbers in this assay, from the lowest: compounds 1 and 2 (each within the scatter of the next); then compounds 3 and 4 (each within the scatter of the next).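

In this assay there is a 1.5-fold higher number from compound 3 to compound 4 (0.18 log units; within the scatter) for 3-hydroxyphenoxy in place of 2-aminoethyl on this chain carbon, so an aromatic ring at this place does not by itself separate the two compounds. Hydrogen in place of cyclohexylcarbamoyl on the oxygen on the aromatic ring brings an 11-fold higher number from compound 2 to compound 4 (1.05 log units; beyond the scatter) in the same read-out, so the large step goes with that cyclohexylcarbamoyl group and not with the ring alone. Nothing at hand accounts for either step.

The compounds shown leave open whether an amine or a carboxylic acid in place of the hydroxyl of 3-hydroxyphenoxy would stay with compound 4 or move towards compound 2. They also leave open how a longer chain would alter these steps.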